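A few compounds are considered here, and "the series" means these few. Any claim that something is new, unique, unknown or untested is made for them only; others in the source may bear on it.

Measured compounds:
Compound 1, `Oc1cccc2cc(-c3ccccc3)ccc12`, gives 20% in an assay for binding affinity to 17-beta-hydroxysteroid dehydrogenase type 2 (Homo sapiens), with a stated time of 20 min, tested at 1 uM; on this read-out higher numbers stand for more inhibition at the one concentration tested (going by the name of the read-out) and lower numbers for less inhibition.
Compound 2, `OCc1ccc(-c2ccc3c(O)cccc3c2)cc1`, gives 31% in this assay.
Compound 3, `CC(=O)c1ccc(-c2ccc3c(O)cccc3c2)cc1`, reaches only a limit of this assay, < 10%.

Compound 3 therefore stands at the floor of the read-out, (the limit of < 10% in this assay, at which 1 of the 3 values shown sits), and no number is known for it. Two measured steps lead to it. From the parent, the change was a number at least 10 percentage points lower from compound 1 to compound 3 (that floor lies within the scatter), a step whose floor lies within the scatter. From compound 2 the change was a number at least 21 percentage points lower from compound 2 to compound 3 (beyond the scatter), a step beyond the scatter. In the other direction, a number 11 percentage points higher from compound 1 to compound 2 (beyond the scatter) shows that the hydroxymethyl group lifted the read-out modestly.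

Compound 4 is `CNS(=O)(=O)c1ccc(-c2ccc3c(O)cccc3c2)cc1`. It differs from compound 3 by methylsulfamoyl in place of acetyl on an aromatic carbon. The entering group, as counted, carries one hydrogen-bond donor where acetyl carried none, which is also what set hydroxymethyl apart from acetyl in the step from compound 2 to compound 3. Compound 4 is therefore expected to rise a number at least 10 percentage points higher from compound 3 to compound 4 (that floor lies within the scatter), back toward the level of compound 1, though the floor of compound 3 leaves the size of that step uncertain. The estimate for compound 4 is 20%, between 5% and 40%.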

Compound 4, a percentage reported as inhibition, at one concentration (the size of the read-out at that concentration, not a potency): 57%
The estimate for compound 4 lay 37 percentage points below the measured number; the measured number lies above the stated range.
By their numbers in this assay, from the lowest: compound 1; then compound 2; then compound 4. At a limit, below all of these: compound 3.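

The earlier compounds shown here showed this position, on an aromatic carbon para to a large group, lifting the read-out in this assay only modestly, whereas methylsulfamoyl shows that it can carry a much larger gain: the change gives a number 37 percentage points higher from compound 1 to compound 4 (beyond the scatter), and against hydroxymethyl it gives a number 26 percentage points higher from compound 2 to compound 4 (beyond the scatter). Against acetyl the change gives a number at least 47 percentage points higher from compound 3 to compound 4 (beyond the scatter), which is a bound and not a size: the limit of < 10% in this assay, at which 1 of the 4 values shown sits. A hydrogen-bond donor in the entering group cannot be the whole story, as hydroxymethyl also differs from acetyl in this way yet stays well short of methylsulfamoyl.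

The compounds shown leave open which part of methylsulfamoyl carries the gain, and whether a plain sulfamoyl, a dimethylsulfamoyl or a methylsulfonyl group would keep it. They also leave open how a longer chain on the sulfonamide nitrogen would read.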